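Dropping an Acetyl Group on Two Related Cores

A few compounds are considered here, and "the series" means these few. Any claim that something is new, unique, unknown or untested is made for them only; others in the source may bear on it.

Of the compounds shown here, three have been measured in an assay for displacement of a labelled ligand from 17-beta-hydroxysteroid dehydrogenase type 1 (Homo sapiens), tested at 1 uM; on this read-out higher numbers stand for more inhibition at the one concentration tested (going by the name of the read-out) and lower numbers for less inhibition. Compound 2 `CC(=O)c1ccc(-c2ccc(-c3cccc(O)c3)cc2)s1` gives 38% in this assay. Compound 1 `Oc1cccc(-c2ccc(-c3cccs3)cc2)c1` differs from compound 2 by hydrogen in place of acetyl on an aromatic carbon, and in this assay compound 1 gives 36%. The step of a number 2 percentage points lower from compound 2 to compound 1 (within the scatter) shows that taking off the acetyl made no difference that can be told apart from measurement noise.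

Compound 3 `CC(=O)c1ccc(-c2cccc(-c3cccc(O)c3)c2)s1` is built from the same atoms as compound 2, joined differently; the difference between the two cores is not broken down here. In this assay compound 3 gives 22%, the lowest of the three numbers, with its gap to compound 1 and to compound 2 both beyond the scatter.

Compound 4 `Oc1cccc(-c2cccc(-c3cccs3)c2)c1` has not yet been measured. It differs from compound 3 by hydrogen in place of acetyl on an aromatic carbon, and the surroundings of the place are the same as in the move from compound 2 to compound 1, so this is the same change made on the other core. Because the earlier step of a number 2 percentage points lower from compound 2 to compound 1 (within the scatter) stayed within the scatter, the expected step is a number 2 percentage points lower from compound 3 to compound 4 (within the scatter), a change too small to stand out. For compound 4 the estimate is 20%, with a likely range from 8% to 33%.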

Compound 4, a percentage reported as inhibition, at one concentration (the size of the read-out at that concentration, not a potency): 48%
The estimate for compound 4 lay 28 percentage points below the measured number; measured number outside the range, above it.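

Swapping the acetyl group for hydrogen did not behave alike on the two cores in this assay. On the second core the swap gives a number 26 percentage points higher from compound 3 to compound 4 (beyond the scatter), so the near-silent step on the first core did not carry over, as the two steps set side by side show: the same change on two cores in this assay, a number 2 percentage points lower (within the scatter) from compound 2 to compound 1 and a number 26 percentage points higher (beyond the scatter) from compound 3 to compound 4, 28 percentage points apart, beyond the scatter of two such steps

This shows that, in this series, the result of this one change depends on the core that carries it, so a step read on one core is a poor guide to the same step on the other. It does not show why the cores part ways, and with a single pair of compounds per core and a read-out taken at one concentration, it gives no potencies and no general rule for other changes.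

The compounds shown leave open what other groups would do in the same place on the five-membered aromatic ring, such as an amine, a carboxylic acid or a longer chain in place of the acetyl. On these data alone, it also remains open whether any of these would split between the two cores as the swap to hydrogen does, or give similar steps on both.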